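The source may report more compounds than this note shows. Statements on the series, on what has been measured and on what is new or still open speak of the compounds shown alone.

Compound 1 `CCOC(=O)[C@H](CCC(=O)O)NC(=O)c1ccc(Sc2nc3cc(N)cc(N)c3nc2-c2ccccc2)cc1`: 8510 nM. Compound 3 `CCOC(=O)[C@H](CCC(=O)O)NC(=O)c1ccc(Oc2nc3cc(N)cc(N)c3nc2-c2ccccc2)cc1`: 26300 nM. Compound 2 `Nc1cc(N)c2nc(-c3ccccc3)c(Oc3ccc(F)cc3)nc2c1`: < 100000 nM, a limit of the assay.

In a functional assay on LOX IMVI cells (Homo sapiens) for inhibition, read by sulforhodamine B assay, with a stated time of 48 h (a higher number here means a weaker inhibitor of growth, a lower number a stronger inhibitor of growth), compound 1 gives 8510 nM and compound 3 gives 26300 nM. For compound 2 this assay reports only a limit, < 100000 nM, so where compound 2 stands among the numbers is not fixed (the limit of < 100000 nM in this assay, at which 1 of the 3 values shown sits). Compound 4 `Nc1cc(N)c2nc(-c3ccccc3)c(NCc3ccc(F)cc3)nc2c1` differs from compound 2 in one place: (4-fluorobenzyl)amino in place of 4-fluorophenoxy on an aromatic carbon. Among the compounds with values here, no pair of measured compounds shares such a change in this assay, so no measured step sets the size or direction of what this change does. Compound 4 is expected to stay in the broad region the three measured compounds occupy, with an expected step from compound 2 of a step that the limit leaves unreadable from compound 2 to compound 4. Compound 4 is estimated at 30000 nM, between 5000 nM and 100000 nM.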

Compound 4, concentration for total growth inhibition: 3160 nM
Beside the measured number, compound 4's estimate is 9.5-fold (0.98 log units) above it; measured number outside the range, below it.
By their numbers in this assay, from the lowest: compound 4; then compound 1; then compound 3.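

The step from compound 2 to compound 4 cannot be read, because compound 2 carries only a limit of the assay: the limit of < 100000 nM in this assay, at which 1 of the 4 values shown sits. The compounds shown leave open how large the effect of (4-fluorobenzyl)amino in place of 4-fluorophenoxy is, and in which direction it runs.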